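A few compounds are considered here, and "the series" means these few. Any claim that something is new, unique, unknown or untested is made for them only; others in the source may bear on it.

Measured in an ADME assay on Caco-2 cells (Homo sapiens) for permeability (on this read-out lower numbers stand for lower permeability and higher numbers for higher permeability), each value being a limit of the assay and not a number:
- Compound 1 `CCCS(=O)(=O)N1CCC(CNC(=O)C2CC2)(C(=O)N2CCOCC2)CC1`: > 22 10^-6 cm/s
- Compound 2 `CCCS(=O)(=O)N1CCC(CNC(=O)c2ccc(F)cc2C(F)(F)F)(C(=O)N2CCOCC2)CC1`: > 22 10^-6 cm/s
- Compound 3 `CCCS(=O)(=O)N1CCC(CNC(=O)c2ccccc2OC(F)(F)F)(C(=O)N2CCOCC2)CC1`: > 22 10^-6 cm/s

In this assay compound 3 gives > 22 10^-6 cm/s, which is a limit. The other two compounds offer no firmer point of comparison, and the whole set sits in one place: the limit of > 22 10^-6 cm/s in this assay, at which 3 of the 3 values shown sit.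

The next compound is compound 4 `CCCS(=O)(=O)N1CCC(CNC(=O)c2c(F)cccc2F)(C(=O)N2CCOCC2)CC1`. It has 2,6-difluorophenyl in place of 2-(trifluoromethoxy)phenyl on a carbonyl carbon, and the count of that change is 2,6-difluorophenyl in place of 2-(trifluoromethoxy)phenyl on a carbonyl carbon.

Going by the values given here, three measured steps bear on this change, all at the same carbonyl carbon. They are a step that the two limits leave unreadable from compound 1 to compound 2, a step that the two limits leave unreadable from compound 1 to compound 3 and a step that the two limits leave unreadable from compound 2 to compound 3. None of them has a readable size, so none can say how far a new group might move the result. What they do show is that cyclopropyl, 4-fluoro-2-(trifluoromethyl)phenyl and 2-(trifluoromethoxy)phenyl all end at the same limit.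

On that basis, no step beyond the usual scatter is expected, in either direction. The expected step is a step that the limit leaves unreadable from compound 3 to compound 4. The assay will probably again report only a limit. For compound 4 the estimated value is 28 10^-6 cm/s, with an expected range from 17 10^-6 cm/s to 45 10^-6 cm/s.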

Compound 4, apparent permeability: > 22 10^-6 cm/s
Compound 4 ended at the assay's limit; the forecaster's own chance of this, stated with the estimate: 75%; the middle value lies beyond the limit too.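

In this assay compound 4 gives > 22 10^-6 cm/s as a limit of the assay and not a number. None of its steps from compound 1, compound 2 or compound 3 can be read, and the whole set sits in one place: the limit of > 22 10^-6 cm/s in this assay, at which 4 of the 4 values shown sit.

How far each of these compounds lies past that limit, and whether they differ from one another at all, remains open.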